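Methoxy on the phenylpiperazine amide: limits only so far

A few compounds are considered here, and "the series" means these few. Any claim that something is new, unique, unknown or untested is made for them only; others in the source may bear on it.

Measured compounds:
compound 1 `COc1ccc(-c2nnc(N3CCN(C(=O)CN4CCN(c5ccccc5)CC4)CC3)nc2-c2ccc(OC)cc2)cc1`: > 863000 nM
compound 2 `COc1ccc(-c2nnc(N3CCN(C(=O)CN4CCN(c5cccc(OC)c5)CC4)CC3)nc2-c2ccc(OC)cc2)cc1`: > 821000 nM
compound 3 `O=C(CN1CCN(c2ccccc2)CC1)N1CCN(c2nnc(-c3ccc(Cl)cc3)c(-c3ccc(Cl)cc3)n2)CC1`: > 850000 nM

In an ADME assay on NIH3T3 cells (Mus musculus) for cytotoxicity, read by MTT assay, with a stated time of 24 h (on this read-out higher numbers stand for weaker inhibition and lower numbers for stronger inhibition), compound 1 gives > 863000 nM, which is a limit of the assay and not a number. In this assay compound 2 gives > 821000 nM, again a limit. In this assay compound 3 gives > 850000 nM, also a limit. Compound 2 differs from compound 1 by methoxy in place of hydrogen on an aromatic carbon; the step that the two limits leave unreadable from compound 1 to compound 2 stays unreadable due to the limit of > 863000 nM in this assay, at which 1 of the 3 values shown sits, and (the limit of > 821000 nM in this assay, at which 1 of the 3 values shown sits). The difference between the cores of compound 1 and compound 3 is not broken down here.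

Compound 4 `COc1ccccc1N1CCN(CC(=O)N2CCN(c3nnc(-c4ccc(Cl)cc4)c(-c4ccc(Cl)cc4)n3)CC2)CC1` has not been measured. It differs from compound 3 by methoxy in place of hydrogen on an aromatic carbon, the same kind of change as from compound 1 to compound 2, though the place is not the same: ortho to a large group here, meta to a large group there.

In this assay the step that the limit leaves unreadable from compound 3 to compound 4 is expected, set beside the earlier one, because the limit for compound 3, > 850000 nM, gives no room to read a direction. The estimate for compound 4 is 1000000 nM, between 400000 nM and 3000000 nM, most likely reported again only as a limit.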

Compound 4, half-maximal inhibitory concentration: 405000 nM
Beside the measured number, compound 4's estimate is 2.5-fold (0.39 log units) above it, and the stated range covers the measured number.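

In this assay, phenyl to 2-methoxyphenyl on the core of compound 3, with the methoxy ortho to a large group, gives an at least 2.0-fold lower number from compound 3 to compound 4 (0.32 log units; beyond the scatter), so on this core the change lowers the number beyond the usual scatter. Going by these compounds, compound 3 gives > 850000 nM, which is a limit and not a number, and the true size of the step remains unknown. The same kind of change on the core of compound 1 sits at a different place on the ring and its step cannot be read, so these data show neither that the lowering carries from one core to the other nor that it fails to carry.

Still open, on these data alone, is how 2-methoxyphenyl behaves on the core of compound 1, which would separate the effect of the core from that of the place on the ring. Also open, as far as these compounds go, is whether a hydroxy group, an amine or a carboxylic acid at the same place on the ring would lower the number as the methoxy does on the core of compound 3.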